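The source may report more compounds than this note shows. Statements on the series, on what has been measured and on what is new or still open speak of the compounds shown alone.

Among the compounds with values here, in an ADME assay on microsomes from liver (Mus musculus) for metabolic stability, read by LC-MS, using NADPH, with a stated time of 10 min, tested at 10 uM (a higher number here means that the compound lasts longer, a lower number that the compound disappears faster), compound 3 `Nc1ncnc2c1c(Oc1cc(Cl)ccn1)nn2[C@H]1C[C@H](F)C1` gives 0.127 h, the higher of the two exact numbers so far. Compound 2 `Nc1ncnc2c1c(Oc1cc(Cl)ccn1)nn2C1CCC1` gives 0.0617 h. Fluoro in place of hydrogen on a saturated ring carbon thus brings a 2.1-fold higher number from compound 2 to compound 3 (0.31 log units; beyond the scatter), a modest step. Compound 4 `Nc1ncnc2c1c(Oc1cc(Cl)ccn1)nn2C1CC1` has cyclopropyl in place of 3-fluorocyclobutyl on an aromatic nitrogen. Losing the fluoro alone would reverse that one measured step, so it points downward. Compound 1 `Nc1ncnc2c1c(Oc1cc(C(F)(F)F)ccn1)nn2C1CC1` also carries cyclopropyl there, and its > 2.41 h is a limit of the assay, not a number. That limit outweighs the modest step, so an upward move beyond the scatter is expected. The expected change is a 3.1-fold higher number from compound 3 to compound 4 (0.50 log units; beyond the scatter). For compound 4 the estimate is 0.4 h, with an expected range from 0.13 h to 1.5 h.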

Compound 4, half-life: 0.233 h
Beside the measured number, compound 4's estimate is 1.7-fold (0.23 log units) above it; low and high end bracket the measured number.
By their numbers in this assay, from the lowest: compound 2; then compounds 3 and 4 (each within the scatter of the next). At a limit, above all of these: compound 1.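

In this assay, cyclopropyl on this aromatic nitrogen gives a 3.8-fold higher number from compound 2 to compound 4 (0.58 log units; beyond the scatter) against cyclobutyl, but a 1.8-fold higher number from compound 3 to compound 4 (0.26 log units; within the scatter) against 3-fluorocyclobutyl, so cyclopropyl and 3-fluorocyclobutyl cannot be told apart here. The bigger change sits elsewhere: chloro in place of trifluoromethyl on an aromatic carbon brings an at least 10-fold lower number from compound 1 to compound 4 (1.01 log units; beyond the scatter). Compound 1 stands at a limit of the assay, not at a number: the limit of > 2.41 h in this assay, at which 1 of the 4 values shown sits.

The compounds shown leave open how an open chain such as isopropyl would fare on this nitrogen. They also leave open what a nitrile would do in place of chloro.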